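Turning One Stereocentre in a Fluorinated Amide

This account rests on a few compounds, and the source may have more. Where it says the series, first, only, none or still open, it means among the compounds named here.

Compound 1 `CC1(C)CC(NC(=O)C(/C=C/[C@@H](NC(=O)OC(C)(C)C)c2ccc(F)cc2)(Cc2ccc(F)cc2)Cc2ccc(F)cc2)CC(C)(C)N1`: 280 nM
Compound 2 `CC(C)C[C@H](/C=C/C(Cc1ccc(F)cc1)(Cc1ccc(F)cc1)C(=O)NC1CC(C)(C)NC(C)(C)C1)NC(=O)OC(C)(C)C`: 180 nM

In a functional assay on HT-1080 cells (Homo sapiens), read by luminescence, with a stated time of 24 h (a lower number here means that less compound is needed, a higher number that more compound is needed for the effect), compound 2 gives 180 nM and compound 1 gives 280 nM, two values within the usual scatter of each other. Compound 3 `CC(C)C[C@@H](/C=C/C(Cc1ccc(F)cc1)(Cc1ccc(F)cc1)C(=O)NC1CC(C)(C)NC(C)(C)C1)NC(=O)OC(C)(C)C` has not yet been measured. Its relation to compound 2 is a change of spatial arrangement alone: the two compounds have the same atoms and bonds and differ only in configuration as drawn: 1 of 2 stereo elements differ; a stereocentre at a saturated chain carbon is drawn R in compound 2 and S in compound 3. Among the compounds with values here, no measured pair shows what such a change does, so the expectation rests on compound 2 at 180 nM. The estimate is a step of a 1.2-fold higher number from compound 2 to compound 3 (0.09 log units; within the scatter), with no direction favoured and none expected beyond the scatter. Compound 3 is expected at 220 nM, with an estimated range of 80 nM to 600 nM.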

Compound 3, half-maximal effective concentration in the HT-1080 assay: 330 nM
Estimate against measurement, compound 3: 1.5-fold (0.18 log units) below; the measured number falls inside the stated range.
By their numbers in the HT-1080 assay, from the lowest: compounds 2, 1 and 3 (each within the scatter of the next).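

In the HT-1080 assay turning this stereocentre from R to S gives a 1.8-fold higher number from compound 2 to compound 3 (0.26 log units; within the scatter). In a physicochemical assay for lipophilicity (on this read-out higher numbers stand for higher lipophilicity and lower numbers for lower lipophilicity), compound 2 gives 7.6 and compound 3 gives 7.6, so the same turn gives no change at the digits printed from compound 2 to compound 3 (within the scatter). This comparison tests the stereocentre alone, because of one fact: the fact that compounds 2 and 3 differ only in the configuration as drawn. In the HT-1080 assay isobutyl in place of 4-fluorophenyl on that carbon gives a 1.2-fold higher number from compound 1 to compound 3 (0.07 log units; within the scatter), so neither change at this position stands out from the scatter.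

Still open, on these data alone, is whether a different group on this carbon, such as an amine or a longer chain, would separate the two configurations beyond the scatter. As far as these compounds go, the effect of turning the stereocentre of compound 1 also remains unknown.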